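Swapping the aryl group on an aromatic amine nitrogen

The source may hold more compounds than are shown below. What is called first, only, known or untested is meant among the compounds shown, and "the series" means these compounds.

Three compounds sharing a urea-linked core were tested in a functional assay on PC-9 cells (Homo sapiens) for inhibition, read by MTT assay, with a stated time of 48 h, tested at 10 uM; a higher number here means more inhibition at the concentration tested (going by the name of the read-out), a lower number less inhibition. Compound 1 `COc1cc(NC(=O)Nc2cc(Nc3cc(Br)ccc3OC)ncn2)cc(OC)c1` gives 82.5%, compound 2 `COc1cc(NC(=O)Nc2cc(Nc3ccc(C)c(F)c3)ncn2)cc(OC)c1` gives 77.5%, and compound 3 `COc1cc(Nc2cc(NC(=O)Nc3c(Cl)cccc3Cl)ncn2)cc(C(F)(F)F)c1` gives 88.5%. Compound 2 thus holds the lowest of the three numbers, though its gap to compound 1 lies within the scatter, while compound 3 sits beyond the scatter above it.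

Compound 4 `COc1cc(NC(=O)Nc2cc(Nc3ccc(OC)c(I)c3)ncn2)cc(OC)c1` differs from compound 2 in one place: 3-iodo-4-methoxyphenyl in place of 3-fluoro-4-methylphenyl on a nitrogen on an aromatic ring. Among the compounds with values here, the only measured step that touches this position is the one from compound 1 to compound 2, where 3-fluoro-4-methylphenyl replaced 5-bromo-2-methoxyphenyl and the result was a number 5 percentage points lower from compound 1 to compound 2 (within the scatter). Moving to 3-iodo-4-methoxyphenyl again brings a halogen and a methoxy group onto that aryl ring, as in compound 1, so no change beyond the scatter is expected in this assay, with at most a small rise.

Compound 4 is therefore estimated at 80%, within a range of 66% to 92%. This corresponds to an expected step of a number 2.5 percentage points higher from compound 2 to compound 4 (within the scatter).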

Compound 4, a percentage reported as inhibition, at one concentration (the size of the read-out at that concentration, not a potency): 47.1%
For compound 4 the middle estimate is 32.9 percentage points above the measured one; the whole stated range lies above it.
By their numbers in this assay, from the lowest: compound 4; then compounds 2, 1 and 3 (each within the scatter of the next, the first and the last beyond it).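

In this assay, the aryl group on this nitrogen turns out to matter a great deal: 3-iodo-4-methoxyphenyl in place of 3-fluoro-4-methylphenyl gives a number 30.4 percentage points lower from compound 2 to compound 4 (beyond the scatter) and, set against 5-bromo-2-methoxyphenyl, gives a number 35.4 percentage points lower from compound 1 to compound 4 (beyond the scatter) as well. The earlier step at this position stayed within the scatter, so it gave no sign that a change here could move the number this far. Compound 1 and compound 4 both carry a halogen and a methoxy group on this ring, so having those two kinds of group does not by itself keep the number high.

Nothing available here accounts for the fall. Still open, as far as these compounds go, is whether the iodine, the methoxy group or their placement on the ring matters most, and how a ring bearing an amine or a carboxylic acid would behave at this nitrogen.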